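From tert-butyl ketone to pentyl ketone

A few compounds are considered here, and "the series" means these few. Any claim that something is new, unique, unknown or untested is made for them only; others in the source may bear on it.

Of the compounds shown here, two with the same core have so far been measured in an assay on microsomes from brain (strain Sprague-Dawley) for inhibition of Fatty-acid amide hydrolase 1 (Rattus norvegicus), read by HPLC, with stated times of 10 min and 45 min; a lower number here means a stronger inhibitor, a higher number a weaker inhibitor. Compound 1 `Cc1cc(C(=O)c2ccccc2)c(C)n1-c1ccc(-c2nnn(C(=O)N(C)C)n2)cc1` carries a phenyl on the carbonyl carbon, and in this assay compound 1 gives 16 nM. Compound 2 `Cc1cc(C(=O)C(C)(C)C)c(C)n1-c1ccc(-c2nnn(C(=O)N(C)C)n2)cc1` carries a tert-butyl at that place, and in this assay compound 2 gives 29 nM. Among the measured compounds shown here, the single measured step, a 1.8-fold higher number from compound 1 to compound 2 (0.26 log units; within the scatter), shows that exchanging the group on the carbonyl carbon left the number essentially where it was. Compound 2 thus stands at the upper end of the two numbers, but the distance to compound 1 is within the scatter, so the two cannot be told apart.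

Compound 3 `CCCCCC(=O)c1cc(C)n(-c2ccc(-c3nnn(C(=O)N(C)C)n3)cc2)c1C` differs from compound 2 in one place: pentyl in place of tert-butyl on a carbonyl carbon. For the measured compounds named here, the only step that bears on this exchange is a 1.8-fold higher number from compound 1 to compound 2 (0.26 log units; within the scatter), and it was small. Because an earlier change at the same place gave a 1.8-fold higher number from compound 1 to compound 2 (0.26 log units; within the scatter), compound 3 is expected to behave much like compound 2. The expected step is a 1.0-fold higher number from compound 2 to compound 3 (0.01 log units; within the scatter), nothing beyond the scatter in either direction. In this assay compound 3 is expected to give about 30 nM, with a range from 10 nM to 90 nM.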

Compound 3, half-maximal inhibitory concentration: 11 nM
The estimate for compound 3 lay 2.7-fold (0.44 log units) above the measured number, and the stated range covers the measured number.
By their numbers in this assay, from the lowest: compounds 3, 1 and 2 (each within the scatter of the next, the first and the last beyond it).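

The earlier exchange at this carbonyl carbon stayed within the scatter, but this one goes beyond it: in this assay, pentyl in place of tert-butyl gives a 2.6-fold lower number from compound 2 to compound 3 (0.42 log units; beyond the scatter), a modest step, so the number does respond to the group placed here. The enzyme inhibition thus distinguishes between these two ring-free groups, although pentyl has only 5 heavy atoms against 4 for tert-butyl, while the comparison with phenyl gives a 1.5-fold lower number from compound 1 to compound 3 (0.16 log units; within the scatter), which lies within the scatter, so pentyl and phenyl cannot be told apart. Phenyl cannot be told apart from tert-butyl either, so only one of the three pairs is separated, and nothing available here accounts for that separation.

The compounds shown cannot say whether the number would keep falling, level off or rise with a longer chain such as heptyl or with a shorter one such as propyl. They also leave open how this position would respond to a chain ending in an amine or a carboxylic acid, groups unlike the plain carbon groups compared so far.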